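Working notes on the amide substituent of the series

The compounds below may be only part of what the source reports. "The series", "measured", "known", "first", "only" and "open" are said of these compounds alone.

Measured so far in a functional assay on MGC-803 cells (Homo sapiens) for inhibition, read by MTT assay, with a stated time of 48 h; a higher number here means a weaker inhibitor, a lower number a stronger inhibitor:
compound 1 `CCCCC(=O)N(Cc1ccc(OC)c(O)c1)c1cc(OC)c(OC)c(OC)c1` gives 66 nM
compound 2 `COc1ccc(CN(C(=O)CN=[N+]=[N-])c2cc(OC)c(OC)c(OC)c2)cc1O` gives 120 nM

Compound 2 stands at the highest of the two numbers; its nearest neighbour is compound 1, and the gap between them, a 1.8-fold higher number from compound 1 to compound 2 (0.26 log units; within the scatter), stays within the scatter, so the two cannot be ranked. The next compound, compound 3 `COc1ccc(CN(C(=O)C(C)C)c2cc(OC)c(OC)c(OC)c2)cc1O`, differs from compound 2 as follows: isopropyl in place of azidomethyl on a carbonyl carbon. Going by the values given here, the only measured step that bears on this change is a 1.8-fold higher number from compound 1 to compound 2 (0.26 log units; within the scatter), an exchange of the group on the carbonyl carbon between an all-carbon chain and an azide-bearing one, which did not move the number beyond the scatter. Compound 3 brings an all-carbon group back to that position, so no step beyond the scatter is expected; the estimated change is a 1.5-fold lower number from compound 2 to compound 3 (0.18 log units; within the scatter). For compound 3 the value in this assay is expected to be 80 nM, with a range of 30 nM to 220 nM.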

Compound 3, half-maximal inhibitory concentration: 210 nM
Compound 3: the middle estimate sits 2.6-fold (0.42 log units) below what was measured; the range from low to high includes it.
By their numbers in this assay, from the lowest: compounds 1, 2 and 3 (each within the scatter of the next, the first and the last beyond it).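

In this assay, going by these compounds alone, the change of isopropyl in place of butyl on a carbonyl carbon gives the first step at this position that lies beyond the scatter, though a modest one: a 3.2-fold higher number from compound 1 to compound 3 (0.50 log units; beyond the scatter). The two all-carbon groups are therefore not interchangeable here, while azidomethyl cannot be ranked against isopropyl, with a 1.8-fold higher number from compound 2 to compound 3 (0.24 log units; within the scatter), and it also lies within the scatter of butyl. No measurement at hand accounts for the difference between butyl and isopropyl.

As far as these compounds go, it remains open whether a longer chain than butyl would hold the number of compound 1 or whether a cyclopropyl ring would behave like isopropyl. Also open, from the compounds shown here alone, is how an amine or a carboxylic acid at the end of the chain on the carbonyl carbon would read in this assay.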